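Swapping a biphenyl tail for a chlorophenyl one

This account rests on a few compounds, and the source may have more. Where it says the series, first, only, none or still open, it means among the compounds named here.

Compound 3, `COC(=O)c1ccc(NCc2cncn2Cc2ccc(-c3ccccc3)cc2)cc1-c1ccccc1`, carries a 4-phenylphenyl group on a saturated chain carbon bound to an aromatic nitrogen. In a toxicity assay on NIH3T3 cells (Mus musculus) for cytotoxicity, read by resazurin assay (a higher number here means that more compound is needed for the effect, a lower number that less compound is needed), compound 3 gives only a limit, > 1000 nM. Two close relatives share its core. Compound 1, `COC(=O)c1ccc(NCc2cncn2Cc2ccc(N)cc2)cc1-c1ccccc1`, also gives only a limit in this assay, > 10000 nM. Compound 2, `COC(=O)c1ccc(NCc2cncn2Cc2ccc([N+](=O)[O-])cc2)cc1-c1ccccc1`, likewise gives only a limit, > 10000 nM. None of the steps among these three can be read as a size: a step that the two limits leave unreadable from compound 1 to compound 3, a step that the two limits leave unreadable from compound 2 to compound 3 and a step that the two limits leave unreadable from compound 1 to compound 2 all fall between the limit of > 1000 nM in this assay, at which 1 of the 3 values shown sits, and (the limit of > 10000 nM in this assay, at which 2 of the 3 values shown sit), so nothing about the measured changes is known beyond the fact that every reading ended at a limit. Compound 4, `COC(=O)c1ccc(NCc2cncn2Cc2cccc(Cl)c2)cc1-c1ccccc1`, differs from compound 3 in one place: 3-chlorophenyl in place of 4-phenylphenyl on a saturated chain carbon bound to an aromatic nitrogen. For the measured compounds named here, no measured step speaks to this replacement, so no shift beyond the scatter is expected in either direction. The step that the limit leaves unreadable from compound 3 to compound 4 is therefore only a rough estimate. Compound 4 is expected to give 20000 nM, within 5000 nM to 100000 nM, most likely again as a limit rather than a number.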

Compound 4, half-maximal effective concentration: > 10000 nM
Compound 4 gave a limit, no number; the forecaster's own chance of this, stated with the estimate: 85%; the middle value lies beyond the limit too.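

In this assay compound 4 also gives only a limit, > 10000 nM, so its steps from compound 1, compound 2 and compound 3 cannot be read as sizes. The compounds shown leave open whether any of these replacements on the saturated chain carbon changes the concentration needed for the effect.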